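This account rests on a few compounds, and the source may have more. Where it says the series, first, only, none or still open, it means among the compounds named here.

In an ADME assay on a cell-free system (plasma, Macaca mulatta) for protein binding, compound 1 `CN(C)C(=O)CCNC(=O)c1cc(-c2ccc(F)cc2)no1` gives 58% and compound 2 `CC(=O)N1CC2(CC(NC(=O)c3cc(-c4ccc(F)cc4)no3)C2)C1` gives 72%. For the measured compounds named here, these two readings lie within the usual scatter of each other, so compound 2 stands level with compound 1 on the numbers so far. The two compounds differ in more than one place, so neither reading shows what a single change does.

Compound 3 `CC(=O)N1CC2(CC(NC(=O)c3cc(-c4ccccc4)no3)C2)C1` is compound 2 with one small edit: hydrogen in place of fluoro on an aromatic carbon. In words, hydrogen takes the place of fluoro on an aromatic carbon, turning 4-fluorophenyl into phenyl. Going by the values given here, no measured pair shows this swap, so the expectation is cautious: a slight shift towards less binding, no larger than the scatter. The estimate is a 1.3-fold higher unbound fraction from compound 2 to compound 3 (0.10 log units; within the scatter), a step expected to stay within the scatter. In this assay compound 3 is expected at 65%, with an estimated range of 50% to 78%.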

Compound 3, plasma protein binding in the Macaca mulatta assay: 59%
The estimate for compound 3 lay 1.2-fold (0.07 log units) (unbound fraction) below the measured number, and the stated range covers the measured number.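

For the compounds shown here, compound 2 and compound 3 are the first measured pair that differ in one place only, so the change from 4-fluorophenyl to phenyl can now be read on its own: in the Macaca mulatta assay it gives a 1.5-fold higher unbound fraction from compound 2 to compound 3 (0.17 log units; within the scatter) and so stays within the scatter. On this evidence, the fluoro group at this position makes no clear difference to the reading. In a physicochemical assay for solubility, at pH 1.2 (on this read-out higher numbers stand for higher solubility and lower numbers for lower solubility), compound 2 gives > 100 ug/mL, which is a limit of the assay and not a number. In the physicochemical assay compound 3 gives > 100 ug/mL, which is also a limit of the assay and not a number. In the physicochemical assay the same step cannot be read, because both compounds sit at a limit of the assay and not at a number: the limit of > 100 ug/mL in the physicochemical assay, at which 2 of the 2 values shown sit.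

Going by these compounds, it remains open whether a chlorine atom, a methoxy group or an amine at this position would shift the reading in the Macaca mulatta assay beyond the scatter. On these data alone, it is also open whether the change from 4-fluorophenyl to phenyl would read the same way on the core of compound 1.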